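Working Notes on the Step from Compound 2 to Compound 3

The source may report more compounds than this note shows. Statements on the series, on what has been measured and on what is new or still open speak of the compounds shown alone.

The series is followed in a functional assay on GBM2 cells (Homo sapiens) for antiproliferative activity, read by WST assay, with a stated time of 72 h; on this read-out lower numbers stand for stronger inhibition and higher numbers for weaker inhibition. Compound 1 `O=C(Nc1cccc(Cl)c1)Nc1cc2ncncc2cc1OCc1ccccc1Cl` gives 2100 nM. Compound 2 `O=C(Nc1cc2ncncc2cc1OCc1ccccc1Cl)Nc1cccc2ccccc12` gives 2900 nM. Compound 2 thus carries the highest of the two numbers, with compound 1 nearest, and the step of a 1.4-fold higher number from compound 1 to compound 2 (0.14 log units; within the scatter) lies within the scatter, so the two cannot be ordered.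

Compound 3 `O=C(Nc1cc2ncncc2cc1OCc1ccc(F)cc1)Nc1cccc2ccccc12` has not yet been measured. It differs from compound 2 by 4-fluorophenyl in place of 2-chlorophenyl on a saturated chain carbon bound to an oxygen on an aromatic ring. Among the compounds with values here, the only measured step, a 1.4-fold higher number from compound 1 to compound 2 (0.14 log units; within the scatter), alters the group on an amide-type nitrogen and leaves the (2-chlorobenzyl)oxy side untouched, so no measured step bears on a change at this place. The two measured values give no basis for expecting a step in this assay beyond the scatter in either direction. Compound 3 is accordingly estimated at 2900 nM, with a range of 900 nM to 9000 nM. Going by these compounds, the step this estimate means is no change at the digits printed from compound 2 to compound 3 (within the scatter), expected to stay within the scatter; the range is kept wide since the change is untested here.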

Compound 3, half-maximal inhibitory concentration: 4500 nM
Compound 3: the middle estimate sits 1.6-fold (0.19 log units) below what was measured; measured number inside the range.
By their numbers in this assay, from the lowest: compounds 1, 2 and 3 (each within the scatter of the next, the first and the last beyond it).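

Within the data shown here, the first measured change at this place, on a saturated chain carbon bound to an oxygen on an aromatic ring, is read in this assay as a 1.6-fold higher number from compound 2 to compound 3 (0.19 log units; within the scatter) and so does not order the two compounds. The earlier step altered only the group on an amide-type nitrogen, whereas this one shows that, with naphthalen-1-yl held fixed, 2-chlorobenzyl and 4-fluorobenzyl cannot be told apart on this read-out, although the two groups differ both in the halogen and in the numbered ring position it occupies. No supporting data accompany this result, and nothing at hand offers an explanation for it.

Going by these compounds, what remains open is whether this place responds at all to a larger change, such as an unsubstituted benzyl group, a plain alkyl chain, or a chain ending in an amine or a carboxylic acid in place of the halogenated phenyl ring. Also open, on these data alone, is whether (4-fluorobenzyl)oxy reads the same when 3-chlorophenyl replaces naphthalen-1-yl on the amide-type nitrogen, which would show whether the two places can be treated separately.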